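The source may hold more compounds than are shown below. What is called first, only, known or untested is meant among the compounds shown, and "the series" means these compounds.

Of the compounds shown here, three have numbers so far in a functional assay on HT-29 cells (Homo sapiens) for inhibition, read by sulforhodamine B assay, with a stated time of 48 h; on this read-out higher numbers stand for weaker inhibition of growth and lower numbers for stronger inhibition of growth. Compound 1 `c1cc(OC2CCCCCC2)ccc1NC1=NCCO1` gives 16600 nM and compound 2 `Cc1ccc(NC2=NCCO2)cc1` gives 13000 nM with these two values lying within the usual scatter of each other. Compound 3 `O=C(CCl)NC(=O)Nc1ccc(C2CCCCC2)cc1` gives 2300 nM as the lowest of the three numbers, and its gaps to both other compounds lie beyond the scatter, so it inhibits growth most strongly of the three.

Compound 4 `O=C(CCl)NC(=O)Nc1ccc(OC2CCCCC2)cc1` differs from compound 3 in one place: cyclohexyloxy in place of cyclohexyl on an aromatic carbon. No measured pair among these compounds shows this change on its own, so any forecast is a judgement and not a reading from the data. The starting point is compound 3 at 2300 nM and the rest of its structure stays untouched, which points to a value of similar size. Compound 1 at 16600 nM also has a ring joined through oxygen, but its core differs, so it only gives a reason to keep the expected range wider on the upper side.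

The expected change (a 1.2-fold higher number from compound 3 to compound 4 (0.09 log units; within the scatter)) lies within the scatter, with no firm direction. In this assay the expected value for compound 4 is 2800 nM with an estimated range from 1100 nM to 7000 nM on that scale.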

Compound 4, concentration for 50% growth inhibition: 3100 nM
Estimate against measurement, compound 4: 1.1-fold (0.04 log units) below; the range from low to high includes it.
By their numbers in this assay, from the lowest: compounds 3 and 4 (each within the scatter of the next); then compounds 2 and 1 (each within the scatter of the next).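

In this assay, going by these compounds alone, cyclohexyloxy in place of cyclohexyl gives a 1.3-fold higher number from compound 3 to compound 4 (0.13 log units; within the scatter) and this is the first direct comparison of two compounds that differ in only one place. At this position, on an aromatic carbon para to a group of 8 heavy atoms, the oxygen that now links the carbon ring to the aromatic ring brings a hydrogen-bond acceptor that cyclohexyl lacks, yet the two compounds cannot be told apart in this read-out. This holds for this one pair only, and nothing available offers an explanation for the result.

From the compounds shown here alone, what stays open is how far this position accepts other kinds of group, such as an amine, a carboxylic acid or a longer chain like n-octyl, since both groups compared here carry the same carbon ring. Also open, going by these compounds, is whether the same change would read alike on a different core, such as that of compound 1, rather than on the shared core of compound 3 and compound 4.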